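The source may hold more compounds than are shown below. What is called first, only, known or untested is meant among the compounds shown, and "the series" means these compounds.

In an assay on HEK293 cells for inhibition of Voltage-dependent T-type calcium channel subunit alpha-1G (Homo sapiens), read by fluorescence, tested at 10 uM (on this read-out lower numbers stand for less inhibition and higher numbers for more inhibition at the one concentration tested (going by the name of the read-out)), three compounds have been measured:

Compound 1 `CCCc1nc(-c2ccccc2)c(CNCCCN2CCN(c3ccccc3)CC2)o1` gives 43.7%.
Compound 2 `CCCc1nc(-c2ccccc2)c(CNCCCN2CCN(c3cccc(OC)c3)CC2)o1` gives 36.4%.
Compound 3 `CCCc1nc(-c2ccccc2)c(CNCCCN2CCN(c3cccc(C)c3C)CC2)o1` gives 55.2%.

Compound 1 stands second highest of the three numbers; compound 2 is within the scatter of it, while compound 3 is beyond it. The step of a number 7.3 percentage points lower from compound 1 to compound 2 (within the scatter) comes from a methoxy in place of hydrogen on an aromatic carbon, and the step of a number 11.5 percentage points higher from compound 1 to compound 3 (beyond the scatter) from 2,3-dimethylphenyl in place of phenyl on an amine nitrogen in a ring.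

Compound 4 `CCCc1nc(-c2ccccc2)c(CNCCCN2CCN(c3cccc(C)c3)CC2)o1` differs from compound 1 by methyl in place of hydrogen on an aromatic carbon. Both known steps on this ring bear on it: the methoxy step was within the scatter, and the dimethyl step was a modest rise. A single methyl lies between these cases, so a small rise at most is expected, possibly none beyond the scatter. Compound 4 is therefore estimated at 49%, with a range from 35% to 63%, meaning an expected step of a number 5.3 percentage points higher from compound 1 to compound 4 (within the scatter).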

Compound 4, a percentage reported as inhibition, at one concentration (the size of the read-out at that concentration, not a potency): 47.8%
Compound 4: middle estimate off by 1.2 percentage points, on the high side; measured number inside the range.
By their numbers in this assay, from the lowest: compounds 2, 1, 4 and 3 (each within the scatter of the next, the first and the last beyond it).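

With a number 4.1 percentage points higher from compound 1 to compound 4 (within the scatter) as the step from phenyl to 3-methylphenyl, a single methyl at this place cannot be told apart from hydrogen. Taking away the second methyl of compound 3 gives a number 7.4 percentage points lower from compound 3 to compound 4 (within the scatter) and cannot be resolved either, although the two methyls together, comparing compound 1 with compound 3, do clear the scatter. Methyl in place of methoxy at this same place gives a number 11.4 percentage points higher from compound 2 to compound 4 (beyond the scatter) and is the one new step beyond the scatter, so the choice of group here can count even where adding one methyl does not.

Nothing measured here explains why methyl and methoxy read differently at this place. Also open, from the compounds shown here alone, is how a chlorine atom, a trifluoromethyl group or an amine would read at this place.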